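From 3-fluorophenyl to 3-hydroxyphenyl: working notes on compound 4

A few compounds are considered here, and "the series" means these few. Any claim that something is new, unique, unknown or untested is made for them only; others in the source may bear on it.

In a functional assay on NCI-H460 cells (Homo sapiens) for inhibition, read by CCK-8 assay, with a stated time of 72 h, tested at 1 uM (a lower number here means less inhibition of growth, a higher number more inhibition of growth at the concentration tested), compound 1 `CN(C)C(=O)c1cc2cnc(Nc3ccc(NC(=O)C4(C(=O)Nc5ccc(F)cc5)CC4)cc3)nc2n1C1CCCC1` gives 79.9%, compound 2 `CN(C)C(=O)c1cc2cnc(Nc3ccc(NC(=O)C4(C(=O)Nc5ccc(Cl)cc5)CC4)cc3)nc2n1C1CCCC1` gives 21.3% and compound 3 `CN(C)C(=O)c1cc2cnc(Nc3ccc(NC(=O)C4(C(=O)Nc5cccc(F)c5)CC4)cc3)nc2n1C1CCCC1` gives 45.1%. Compound 3 stands second highest of the three, and the data show a number 34.8 percentage points lower from compound 1 to compound 3 (beyond the scatter) and a number 23.8 percentage points higher from compound 2 to compound 3 (beyond the scatter).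

Compound 4 `CN(C)C(=O)c1cc2cnc(Nc3ccc(NC(=O)C4(C(=O)Nc5cccc(O)c5)CC4)cc3)nc2n1C1CCCC1` differs from compound 3 by hydroxy in place of fluoro on an aromatic carbon, meta to a large group. Among the measured compounds shown here, no measured compound carries a hydroxy, so no step transfers directly. The closest evidence is the one measured replacement of fluoro by another group, a number 58.6 percentage points lower from compound 1 to compound 2 (beyond the scatter), which sets the direction as downward. The same step and a number 34.8 percentage points lower from compound 1 to compound 3 (beyond the scatter) also show that single changes on this aromatic ring can be large in this set of three, so a wide range is warranted and a rise cannot be excluded.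

The expected change is modest, an estimated a number 7.1 percentage points lower from compound 3 to compound 4 (within the scatter). Compound 4 is estimated at 38%, with an expected range of 14% to 68%.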

Compound 4, percent growth inhibition at one concentration: 75.5%
Estimate against measurement, compound 4: 37.5 percentage points below, outside the stated range (above it).
By their numbers in this assay, from the lowest: compound 2; then compound 3; then compounds 4 and 1 (each within the scatter of the next).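

In this assay replacing fluoro on an aromatic carbon can raise the number as well as lower it (a number 30.4 percentage points higher from compound 3 to compound 4 (beyond the scatter)), so the fall seen for the chloro replacement does not hold for every group entering the ring. The 3-hydroxyphenyl amide also stands far from the 4-chlorophenyl amide (a number 54.2 percentage points higher from compound 2 to compound 4 (beyond the scatter)) and cannot be separated from the 4-fluorophenyl amide (a number 4.4 percentage points lower from compound 1 to compound 4 (within the scatter)), so leaving the 4-fluorophenyl group need not cost growth inhibition, although it does in compound 3. No measurement shown accounts for the effect of the hydroxy group.

The compounds shown leave open whether an amino or methoxy group in the same place would match the hydroxy group. They also leave open whether the parity between compound 4 and compound 1 holds at other concentrations.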